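The source may hold more compounds than are shown below. What is called first, only, known or untested is meant among the compounds shown, and "the series" means these compounds.

Compound 1, `CCCCNc1nc(N)nc2c1CNCC2`: 7.2 uM
Compound 2, `CCCCNc1nc(N)nc2c1CN(C(C)=O)CC2`: 0.5 uM
Compound 3, `CCCCNc1nc(N)nc2c1CN(Cc1ccccn1)CC2`: 0.07 uM

All three were measured in an assay on HEK293 cells for agonist activity at Toll-like receptor 8 (Homo sapiens), read by a luciferase reporter, with a stated time of 6 h; a higher number here means that more compound is needed for the effect, a lower number that less compound is needed. Compound 3 gives the lowest number of the three; the step of a 7.1-fold lower number from compound 2 to compound 3 (0.85 log units; beyond the scatter) and the step of a 100-fold lower number from compound 1 to compound 3 (2.01 log units; beyond the scatter) both lie beyond the scatter. Compound 4, `CCCCNc1nc(N)nc2c1CN(C(=O)CC)CC2`, has not yet been measured. It differs from compound 3 in one place: propanoyl in place of (pyridin-2-yl)methyl on an amine nitrogen in a ring. The measured step that bears most directly on this change runs the other way, a 7.1-fold lower number from compound 2 to compound 3 (0.85 log units; beyond the scatter), where an acetyl gave way to the (pyridin-2-yl)methyl; propanoyl, like acetyl, is an acyl group with a carbonyl and no ring. The step of a 14-fold lower number from compound 1 to compound 2 (1.16 log units; beyond the scatter) shows that such an acyl group on this nitrogen already brings the number well below that of the bare amine of compound 1. Compound 4 is therefore expected to show the step of a 5.7-fold higher number from compound 3 to compound 4 (0.76 log units; beyond the scatter), a higher number, meaning more compound is needed. The estimate for compound 4 is 0.4 uM, with a range from 0.1 uM to 1.5 uM.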

Compound 4, minimum effective concentration: 0.4 uM
Compound 4: middle estimate and measured number agree at the digits printed; the range from low to high includes it.
By their numbers in this assay, from the lowest: compound 3; then compounds 4 and 2 (each within the scatter of the next); then compound 1.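

In this assay, a methyl in place of hydrogen on the saturated chain carbon bound to the carbonyl carbon makes no difference that can be read (a 1.3-fold lower number from compound 2 to compound 4 (0.10 log units; within the scatter)). The large drop from the bare amine is thus not confined to acetyl, since propanoyl gives it too (an 18-fold lower number from compound 1 to compound 4 (1.26 log units; beyond the scatter)). The gap to the (pyridin-2-yl)methyl group likewise holds with a second acyl group (a 5.7-fold higher number from compound 3 to compound 4 (0.76 log units; beyond the scatter)), so among these compounds the two acyl groups stand together and compound 3 stands apart. The compounds shown leave open whether a longer acyl chain such as butanoyl, a benzoyl group, or a plain benzyl group in place of the (pyridin-2-yl)methyl would follow the same order. No measurement here gives a reason for these differences.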